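The source may report more compounds than this note shows. Statements on the series, on what has been measured and on what is new or still open speak of the compounds shown alone.

Compound 1, `COc1ccccc1/C=C1\CCC/C(=C\c2cccc(OC)c2OC)C1=O`, was tested in a functional assay on HT-1080 cells (Homo sapiens) for cytotoxicity, read by MTT assay, with a stated time of 72 h (a lower number here means a stronger inhibitor, a higher number a weaker inhibitor), and gave 14100 nM. Among the numbers recorded, this is the highest of the two that are plain numbers; its nearest neighbour is compound 3, `COc1cc(/C=C2\CCC/C(=C\c3cccc(OC)c3OC)C2=O)cc(OC)c1`, which in this assay gives 4500 nM, a difference beyond the usual scatter. Compound 2, `COc1ccc(/C=C2\CCC/C(=C\c3cccc(OC)c3OC)C2=O)c(OC)c1`, reached only a limit of the assay: in this assay compound 2 gives > 20000 nM. That limit is the one described by the limit of > 20000 nM in this assay, at which 1 of the 3 values shown sits.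

Within the data shown here, the only measured step that starts from compound 1 is an at least 1.4-fold higher number from compound 1 to compound 2 (0.15 log units; that floor lies within the scatter), and it adds a methoxy group at an aromatic carbon; it says little, since its floor sits within the scatter.

Compound 4, `COc1cccc(/C=C2\CCC/C(=C\c3ccc(O)c(O)c3)C2=O)c1OC`, differs from compound 1 by 3,4-dihydroxyphenyl in place of 2-methoxyphenyl on a double-bonded chain carbon bound to a double-bonded ring carbon. Among the measured compounds shown here, no measured step swaps a methoxy-bearing ring for a ring carrying two hydroxyl groups, so the expectation rests on the weak hint from compound 3 that changing the substitution of this ring can lower the number. The estimated step is a 2.8-fold lower number from compound 1 to compound 4 (0.45 log units; beyond the scatter), toward a stronger inhibitor, though with wide uncertainty. Compound 4 is therefore expected to give about 5000 nM, somewhere between 1500 nM and 16000 nM.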

Compound 4, half-maximal inhibitory concentration: 4700 nM
Beside the measured number, compound 4's estimate is 1.1-fold (0.03 log units) above it; the measured number falls inside the stated range.
By their numbers in this assay, from the lowest: compounds 3 and 4 (each within the scatter of the next); then compound 1. At a limit, above all of these: compound 2.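

In this assay, putting 3,4-dihydroxyphenyl in place of 2-methoxyphenyl on a double-bonded chain carbon bound to a double-bonded ring carbon gives a 3.0-fold lower number from compound 1 to compound 4 (0.48 log units; beyond the scatter) and so shows that this place responds to a change of ring and accepts hydroxyl groups without a loss. The earlier step from compound 1 added a methoxy group and gave only a floor within the scatter, so it could not show this. Hydroxyl groups are not needed to reach this level, however: compound 3, whose variable ring carries only methoxy groups, gives 4500 nM and compound 4 gives 4700 nM (two values within the scatter of each other).

Nothing in the data at hand explains why the number falls with this change. On these data alone, it also remains open whether both hydroxyl groups are needed, and how a ring carrying an amine or a carboxylic acid would behave at this place.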